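Swapping 2-methylphenyl for 3,4-difluorophenyl on an amide-type nitrogen

The source may hold more compounds than are shown below. What is called first, only, known or untested is meant among the compounds shown, and "the series" means these compounds.

Of the compounds shown here, three sharing one core have been measured in a functional assay on A549 cells (Homo sapiens) for cytotoxicity, read by MTT assay, with a stated time of 72 h; on this read-out higher numbers stand for weaker inhibition and lower numbers for stronger inhibition. Compound 1 `COc1ccc(NC(=O)CN2CCN(c3nnc(Cc4ccncc4)c4ccccc34)CC2)cc1OC` gives 26500 nM, compound 2 `Cc1ccc(F)cc1NC(=O)CN1CCN(c2nnc(Cc3ccncc3)c3ccccc23)CC1` gives 38900 nM, and compound 3 `Cc1ccccc1NC(=O)CN1CCN(c2nnc(Cc3ccncc3)c3ccccc23)CC1` gives 43100 nM. Compound 3 therefore stands within the scatter of both others, as shown by a 1.1-fold higher number from compound 2 to compound 3 (0.04 log units; within the scatter) and by a 1.6-fold higher number from compound 1 to compound 3 (0.21 log units; within the scatter).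

Compound 4 `O=C(CN1CCN(c2nnc(Cc3ccncc3)c3ccccc23)CC1)Nc1ccc(F)c(F)c1` carries 3,4-difluorophenyl in place of 2-methylphenyl on an amide-type nitrogen. The measured steps that bear on this change all alter the same aryl group. Besides the two above, there is a 1.5-fold higher number from compound 1 to compound 2 (0.17 log units; within the scatter), and none of the three goes beyond the scatter. Among the compounds with values here, no measured compound carries 3,4-difluorophenyl, so this group itself remains untested.

On this evidence, no step beyond the scatter is expected, and the estimated step is a 1.2-fold lower number from compound 3 to compound 4 (0.09 log units; within the scatter). For compound 4 the expected value is 35000 nM, with an estimated range from 18000 nM to 70000 nM.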

Compound 4, half-maximal inhibitory concentration: 3790 nM
The estimate for compound 4 lay 9.2-fold (0.97 log units) above the measured number, outside the stated range (below it).
By their numbers in this assay, from the lowest: compound 4; then compounds 1, 2 and 3 (each within the scatter of the next).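

In this assay, within the data shown here, the aryl group on the amide-type nitrogen turns out to be able to shift the number beyond the scatter, something the earlier compounds did not show: there is an 11-fold lower number from compound 3 to compound 4 (1.06 log units; beyond the scatter) and a 10-fold lower number from compound 2 to compound 4 (1.01 log units; beyond the scatter) as well as a 7.0-fold lower number from compound 1 to compound 4 (0.84 log units; beyond the scatter). Fluoro alone does not go with the shift, since compound 2 also carries it and still stays within the scatter of compound 3, with a 1.1-fold higher number from compound 2 to compound 3 (0.04 log units; within the scatter). Nothing available here explains why 3,4-difluorophenyl stands apart from the other aryl groups.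

As far as these compounds go, whether both fluoro groups are needed for the lower number remains open. From the compounds shown here alone, it is also open how a plain phenyl, or an aryl group carrying chloro or trifluoromethyl, would read at this position.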